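Shortening the selenium chain: from compound 2 to compound 3

The compounds below may be only part of what the source reports. "The series", "measured", "known", "first", "only" and "open" are said of these compounds alone.

Measured so far:
compound 1 `C[Se]c1ccc(N(C)c2nc(C)nc3ccccc23)cc1C`: 3 nM
compound 2 `COc1ccc(N(C)c2nc(C)nc3ccccc23)cc1OCCCCC[Se]C#N`: 256 nM

In a functional assay on HCT-116 cells (Homo sapiens) for inhibition, read by MTT assay, with a stated time of 48 h (on this read-out higher numbers stand for weaker inhibition and lower numbers for stronger inhibition), compound 2 gives 256 nM, the highest of the two numbers. Going by the values given here, compound 1 gives 3 nM, and the gap between these two lies well beyond the scatter; no single-point step connects them. Compound 3 `COc1ccc(N(C)c2nc(C)nc3ccccc23)cc1OCCC[Se]C#N` differs from compound 2 by a group of 3 heavy atoms (1 carbon, 1 nitrogen, 1 selenium; no ring) in place of a group of 5 heavy atoms (3 carbon, 1 nitrogen, 1 selenium; no ring), on a saturated chain carbon, three bonds along the chain from an oxygen on an aromatic ring. Among the compounds with values here, no measured step of this kind exists, so the change is expected to be modest and without a clear direction, likely within the scatter a 1.2-fold higher number from compound 2 to compound 3 (0.07 log units; within the scatter). Compound 3 is expected at 300 nM, with a range from 100 nM to 900 nM.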

Compound 3, half-maximal inhibitory concentration: 852 nM
For compound 3 the middle estimate is 2.8-fold (0.45 log units) below the measured one; low and high end bracket the measured number.
By their numbers in this assay, from the lowest: compound 1; then compound 2; then compound 3.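

In this assay, going by these compounds alone, the length of the selenium chain matters: the group of 3 heavy atoms in place of the group of 5 heavy atoms gives a 3.3-fold higher number from compound 2 to compound 3 (0.52 log units; beyond the scatter) and is the first single-place step. Of this pair, the longer chain carries the lower number. No measured data on this change are available to account for the step. Still open, as far as these compounds go, is whether a longer chain would lower the number further, and whether an amine at the chain end would keep this activity.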